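Removing a methyl group from compound 2

The source may hold more compounds than are shown below. What is called first, only, known or untested is meant among the compounds shown, and "the series" means these compounds.

Of the compounds shown here, two have been measured so far. Going by the values given here, in a functional assay on A2780 cells (Homo sapiens) for antiproliferative activity, read by MTT assay, with a stated time of 72 h (a lower number here means a stronger inhibitor, a higher number a weaker inhibitor), compound 1 (`COc1cc(/C=C\c2cc3cc(F)ccc3s2)cc(OC)c1OC`) gives 200 nM and compound 2 (`COc1cc(/C=C\c2sc3ccccc3c2C)cc(OC)c1OC`) gives 360 nM, so compound 2 stands within the scatter of the only other number available. Compound 3 (`COc1cc(/C=C\c2cc3ccccc3s2)cc(OC)c1OC`) differs from compound 2 at one place, with hydrogen in place of methyl on an aromatic carbon. Among the compounds with values here, no measured pair shows this change alone. Within the data shown here, compound 1 has hydrogen on that carbon but differs elsewhere too, and its 200 nM is the only guide in this assay for such a compound. A small move toward a lower number is therefore expected, with the estimated 1.8-fold lower number from compound 2 to compound 3 (0.26 log units; within the scatter) not passing the scatter. For compound 3 the expected value is 200 nM with an estimated range from 60 nM to 650 nM as the likely span of a measurement.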

Compound 3, half-maximal inhibitory concentration: 7.9 nM
For compound 3 the middle estimate is 25-fold (1.40 log units) above the measured one; measured number outside the range, below it.
By their numbers in this assay, from the lowest: compound 3; then compounds 1 and 2 (each within the scatter of the next).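

In this assay, going by these compounds alone, the single change from methyl to hydrogen on this aromatic carbon, two ring bonds from the ring sulfur, gives a 46-fold lower number from compound 2 to compound 3 (1.66 log units; beyond the scatter) and so reveals a sensitivity that the closeness of compound 1 and compound 2 had not suggested. Hydrogen in place of fluoro on an aromatic carbon gives a 25-fold lower number from compound 1 to compound 3 (1.40 log units; beyond the scatter) as well, which leaves compound 3, carrying neither group, with the lowest number of the three and both of its steps beyond the scatter. Nothing available explains why either substituent is accompanied by such a rise in the number.

With methyl the only group shown on this carbon, it remains open whether an ethyl group, a chlorine atom or an amine there would behave in the same way. The compounds also leave open whether fluoro keeps its step when it is placed on other carbons of the shared core.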